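Trifluoromethyl for methyl on the acetyl group

This account rests on a few compounds, and the source may have more. Where it says the series, first, only, none or still open, it means among the compounds named here.

Measured compounds:
compound 1 `CCN(C(=O)N(C)C)c1cc2oc(-c3ccc(F)cc3)c(C(=O)NC)c2cc1-c1ccc(OC)c(C(=O)NC2(c3ncccn3)CC2)c1` — 575 nm/s
compound 2 `CCN(C(C)=O)c1cc2oc(-c3ccc(F)cc3)c(C(=O)NC)c2cc1-c1ccc(OC)c(C(=O)NC2(c3ncccn3)CC2)c1` — 466 nm/s

In an ADME assay for permeability, using PAMPA, at pH 7.4 (a higher number here means that the compound crosses the layer faster, a lower number that the compound crosses the layer more slowly), compound 2 gives 466 nm/s, and compound 1 gives 575 nm/s; these two numbers sit within the scatter of each other. Going by the values given here, the single measured step reads a 1.2-fold lower number from compound 1 to compound 2 (0.09 log units; within the scatter). Compound 3 `CCN(C(=O)C(F)(F)F)c1cc2oc(-c3ccc(F)cc3)c(C(=O)NC)c2cc1-c1ccc(OC)c(C(=O)NC2(c3ncccn3)CC2)c1` differs from compound 2 by trifluoromethyl in place of methyl on a carbonyl carbon. Among the compounds with values here, that earlier step, also a change on the same carbonyl carbon, is the only one bearing on this change, and it was small. Because a 1.2-fold lower number from compound 1 to compound 2 (0.09 log units; within the scatter) stayed within the scatter, no step beyond the scatter is expected here, so compound 3 is estimated at 500 nm/s, within 300 nm/s to 850 nm/s, an expected step of a 1.1-fold higher number from compound 2 to compound 3 (0.03 log units; within the scatter).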

Compound 3, apparent permeability: 835 nm/s
The estimate for compound 3 lay 1.7-fold (0.22 log units) below the measured number; the measured number falls inside the stated range.
By their numbers in this assay, from the lowest: compounds 2, 1 and 3 (each within the scatter of the next).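

In this assay this carbonyl carbon now carries a third group, and trifluoromethyl gives a reading in line with the other two: a 1.8-fold higher number from compound 2 to compound 3 (0.25 log units; within the scatter) and a 1.5-fold higher number from compound 1 to compound 3 (0.16 log units; within the scatter). Methyl, dimethylamino and trifluoromethyl on this carbon thus all stay within the scatter of one another, so these three groups cannot be told apart here. Nothing measured here accounts for this result. As far as these compounds go, whether a group of a different kind on this carbonyl carbon, such as a carboxylic acid, an amine or a longer carbon chain, would step beyond the scatter remains open.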